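A few compounds are considered here, and "the series" means these few. Any claim that something is new, unique, unknown or untested is made for them only; others in the source may bear on it.

In an ADME assay on CCRF-CEM cells (Homo sapiens) for antiproliferative activity, with a stated time of 48 h (a higher number here means a weaker inhibitor, a lower number a stronger inhibitor), the measured compounds are compound 1 `C=C(Br)C(=O)Nc1ccc(/C=C/C(=O)c2ccc(F)cc2)cc1` (1100 nM), compound 2 `C=C(Br)C(=O)Nc1ccc(/C=C/C(=O)c2ccc(Br)cc2)cc1` (990 nM) and compound 3 `C=C(Br)C(=O)Nc1ccc(/C=C/C(=O)c2ccc(C)cc2)cc1` (1800 nM). Compound 3 cannot be separated from the other two, with a 1.6-fold higher number from compound 1 to compound 3 (0.21 log units; within the scatter) and a 1.8-fold higher number from compound 2 to compound 3 (0.26 log units; within the scatter) both inside the scatter. Compound 4 `C=C(Br)C(=O)Nc1ccc(/C=C/C(=O)c2ccc(OC)cc2)cc1` is the next case, and the change is methoxy in place of methyl on an aromatic carbon, para to a large group (methoxy in place of methyl on an aromatic carbon). Among the compounds with values here, no methoxy compound has been measured, so the only guide is the exchange of fluoro, bromo and methyl on that carbon, where a 1.1-fold lower number from compound 1 to compound 2 (0.05 log units; within the scatter) also stays within the scatter. No step beyond the scatter is therefore expected in this assay and no firm direction can be assigned. The expected step is a 1.1-fold lower number from compound 3 to compound 4 (0.05 log units; within the scatter) and so stays within the scatter. Compound 4 is estimated at 1600 nM with 750 nM to 3300 nM as the expected range.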

Compound 4, half-maximal inhibitory concentration: 1400 nM
The estimate for compound 4 lay 1.1-fold (0.06 log units) above the measured number; measured number inside the range.
By their numbers in this assay, from the lowest: compounds 2, 1, 4 and 3 (each within the scatter of the next).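

In this assay, methoxy on this aromatic carbon, para to a large group, does not separate from any of the three earlier groups (methyl: a 1.3-fold lower number from compound 3 to compound 4 (0.11 log units; within the scatter); bromo: a 1.4-fold higher number from compound 2 to compound 4 (0.15 log units; within the scatter); fluoro: a 1.3-fold higher number from compound 1 to compound 4 (0.10 log units; within the scatter)). Within the data shown here, the change adds an oxygen and a hydrogen-bond acceptor to the group at this position, and for the first time an exchange of this kind has been read with such an atom entering, yet all four compounds remain within the scatter of one another. Nothing at hand bears on why the numbers stay so close.

On these data alone, whether any group at this position can move the number beyond the scatter remains open, for example an amine, a carboxylic acid or a longer chain. Also open, as far as these compounds go, is whether these exchanges stay as flat on a changed core.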